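This account rests on a few compounds, and the source may have more. Where it says the series, first, only, none or still open, it means among the compounds named here.

Measured compounds in this series:

- compound 1, `COc1cc(/C=N/Nc2nc(-c3ccc(Br)cc3)cs2)cc(Br)c1OC`, giving 64600 nM.
- compound 2, `COc1cc(/C=N/Nc2nc(-c3cc(C(F)(F)F)cc(C(F)(F)F)c3)cs2)cc(Br)c1OC`, for which only a limit is recorded: > 100000 nM.
- compound 3, `COc1cc(/C=N/Nc2nc(-c3ccc(Br)cc3)cs2)c(Br)c(Br)c1OC`, for which only a limit is recorded: > 100000 nM.

All values come from a functional assay on HepG2 cells (Homo sapiens) for inhibition, read by MTT assay, with a stated time of 48 h; a lower number here means a stronger inhibitor, a higher number a weaker inhibitor. Among the compounds with values here, the only counted step is an at least 1.5-fold higher number from compound 1 to compound 3 (0.18 log units; that floor lies within the scatter), the change being (bromo in place of hydrogen on an aromatic carbon). The cores of compound 1 and compound 2 differ, but that difference is not broken down here. Compound 4, `COc1cc(/C=N/Nc2nc(-c3cc(C(F)(F)F)cc(C(F)(F)F)c3)cs2)c(Br)c(Br)c1OC`, is not yet measured; it arises from compound 2 by the same change, (bromo in place of hydrogen on an aromatic carbon), with the place described in the same words as for compound 3. Notable is the limit of > 100000 nM in this assay, at which 2 of the 3 values shown sit. Since compound 2 already shows only a limit, compound 4 is expected to give a step that the limit leaves unreadable from compound 2 to compound 4, that is, it is estimated to remain at or beyond that limit. The estimate for compound 4 is 150000 nM, expected within 80000 nM to 500000 nM.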

Compound 4, half-maximal inhibitory concentration: > 100000 nM
Compound 4 gave a limit, no number; the forecaster's own chance of this, stated with the estimate: 85%; the middle value does not contradict the limit.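

Compound 2 and compound 4 both stand only as limits, so no step can be read between them: the limit of > 100000 nM in this assay, at which 3 of the 4 values shown sit.

As far as these compounds go, what bromo in place of hydrogen does to the number when going from compound 2 to compound 4 stays open.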